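This account rests on a few compounds, and the source may have more. Where it says the series, first, only, none or still open, it means among the compounds named here.

Three close relatives built on one shared core have been tested in an ADME assay on MT2 cells (Homo sapiens) for cytotoxicity, read by XTT assay, with a stated time of 4 days; a lower number here means that less compound is tolerated, a higher number that more compound is tolerated. Compound 1, with the structure `Cc1nc(C(NC(=O)C(=O)Nc2ccc(Cl)cc2)C2CCNCC2)sc1CO`, reaches only the limit of the measurement and gives > 81000 nM. Compound 2, with the structure `Cc1nc(C(NC(=O)C(=O)Nc2ccc(Cl)cc2)C2CCCN2)sc1CO`, gives a number in this assay, 45000 nM. Compound 3, with the structure `Cc1nc(C(NC(=O)C(=O)Nc2ccc(Cl)cc2)C2CCCCN2)sc1CO`, again sits at a limit and gives > 108000 nM in this assay. Among the measured steps, an at least 2.4-fold higher number from compound 2 to compound 3 (0.38 log units; beyond the scatter) is the only one beyond the scatter; an at least 1.8-fold lower number from compound 1 to compound 2 (0.25 log units; that floor lies within the scatter) stays within it, and a step that the two limits leave unreadable from compound 1 to compound 3. Compound 3 thus stands at the limit of > 108000 nM in this assay, at which 1 of the 3 values shown sits.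

Compound 4, with the structure `Cc1nc(C(NC(=O)C(=O)NC2CCCCCC2)C2CCCCN2)sc1CO`, differs from compound 3 by cycloheptyl in place of 4-chlorophenyl on an amide-type nitrogen. All three measured steps concern the saturated ring on the other side of the core, not the amide-type nitrogen where this exchange occurs, so none of them bears on the change. No step beyond the scatter is therefore expected, and the step of a number no higher from compound 3 to compound 4 (the limit leaves the size open) is estimated to remain within it. Compound 4 is expected to give about 108000 nM in this assay, within the range 45000 nM to 250000 nM, and may well come back only as a limit once more.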

Compound 4, half-maximal cytotoxic concentration: > 90000 nM
Compound 4: only a limit was reported; the forecaster's own chance of this, stated with the estimate: 65%; the middle value is on the limit's open side.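

Compound 3 and compound 4 both come back only as limits in this assay, not as numbers, so the step between them cannot be read. The compounds shown leave open where the true values of compound 3 and compound 4 lie, and whether cycloheptyl in place of 4-chlorophenyl changes the number at all.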